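Benzylamino for (methylsulfonyl)oxy on the shared core

The source may hold more compounds than are shown below. What is called first, only, known or untested is meant among the compounds shown, and "the series" means these compounds.

Compound 1 `CS(=O)(=O)Oc1c(C(=O)NCc2ccc(F)cc2)nc(Br)c2cccnc12` is the starting point of this note. In a functional assay on HCT-116 cells (Homo sapiens) for cytotoxicity, read by MTT assay, with a stated time of 72 h (on this read-out higher numbers stand for weaker inhibition and lower numbers for stronger inhibition), compound 1 gives only a limit of the assay, > 20000 nM, not a number. Compound 1 therefore sits at the limit of > 20000 nM in this assay, at which 1 of the 3 values shown sits, the only one of the measured set to do so. For the measured compounds named here, compound 2 `COc1cccc(CNC(=O)c2nc(Br)c3cccnc3c2N[C@H]2CC[C@H](N)CC2)c1` is the one member with a single number: in this assay compound 2 gives 6000 nM. Compound 3 `COC(=O)c1nc(Br)c2cccnc2c1N[C@H]1CC[C@H](N)CC1` has no result in this assay, where its entry reads "not determined" (no result reported), so it adds nothing to the comparison.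

The step to compound 4 `O=C(NCc1ccc(F)cc1)c1nc(Br)c2cccnc2c1NCc1ccccc1` changes one site of the core of compound 1: benzylamino in place of (methylsulfonyl)oxy on an aromatic carbon. Going by the values given here, no pair of measured compounds differs in only one place, so the size of this kind of step cannot be read from the data; the only measured point with a number, compound 2 with 6000 nM, shows that members can reach a measurable value in this assay.

Compound 4 is expected to give 9000 nM in this assay, with a range of 2500 nM to 20000 nM. The expected step of an at least 2.2-fold lower number from compound 1 to compound 4 (0.34 log units; beyond the scatter) is taken as a move toward stronger inhibition, but because compound 1 stands at the limit of > 20000 nM in this assay, at which 1 of the 3 values shown sits, a further limit for compound 4 remains a real possibility.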

Compound 4, half-maximal inhibitory concentration: > 20000 nM
Compound 4 was reported as a limit (the forecaster's own chance of this, stated with the estimate: 35%); middle value at least 2.2-fold (0.34 log units) away from the limit.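

No step can be read from compound 1 to compound 4 in this assay, because each of the two compounds gives only a limit of the assay: the limit of > 20000 nM in this assay, at which 2 of the 4 values shown sit.

The compounds shown leave open whether benzylamino in place of (methylsulfonyl)oxy on an aromatic carbon changes the read-out at all, and how far either compound lies past that limit.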